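Cyclohexyl for propyl on the sulfonylurea nitrogen

A few compounds are considered here, and "the series" means these few. Any claim that something is new, unique, unknown or untested is made for them only; others in the source may bear on it.

Compound 3 `CCCNC(=O)NS(=O)(=O)c1ccc(-n2nc(-c3ccc(C)cc3)ccc2=O)cc1` stands at the top of the three numbers in hand, though not clearly apart from its nearest neighbour. In a functional assay on the whole organism (blood, strain Wistar albino) for inhibition, with Rattus norvegicus as the target, read by colorimetric assay, with stated times of 15 min and 90 min, at a dose of 20 mg/kg by the oral route (on this read-out higher numbers stand for more inhibition at the one dose given (going by the name of the read-out) and lower numbers for less inhibition), compound 3 gives 80.5%. Compound 1 `CCCNC(=O)NS(=O)(=O)c1ccc(-n2nc(-c3ccccc3)ccc2=O)cc1` carries hydrogen where compound 3 carries methyl on an aromatic carbon; in this assay compound 1 gives 77.2%, and the step of a number 3.3 percentage points higher from compound 1 to compound 3 (within the scatter) lies within the scatter. Compound 2 `CCCCNC(=O)NS(=O)(=O)c1ccc(-n2nc(-c3ccc(OC)cc3)ccc2=O)cc1` differs from compound 3 in two places at once, with butyl on the amide-type nitrogen and methoxy on the aromatic carbon, and in this assay compound 2 gives 43.7%, well below the other two.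

Compound 4 `Cc1ccc(-c2ccc(=O)n(-c3ccc(S(=O)(=O)NC(=O)NC4CCCCC4)cc3)n2)cc1` is the next step from compound 3: cyclohexyl in place of propyl on an amide-type nitrogen. Within the data shown here, none of the measured steps touches the group on the amide-type nitrogen by itself; the only measured step alters the aromatic carbon and changes nothing beyond the scatter. Compound 2 shows a lower value with a longer chain on that nitrogen, but its second change blurs what that means. The expectation for compound 4 in this assay is therefore a step of a number 12.5 percentage points lower from compound 3 to compound 4 (beyond the scatter) of uncertain direction and size. Compound 4 is estimated at 68%, with a range from 42% to 90%.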

Compound 4, a percentage reported as inhibition, in the whole organism at one dose (the size of the read-out at that dose, not a potency): 79.9%
For compound 4 the middle estimate is 11.9 percentage points below the measured one; the measured number falls inside the stated range.
By their numbers in this assay, from the lowest: compound 2; then compounds 1, 4 and 3 (each within the scatter of the next).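

In this assay the step of a number 0.6 percentage points lower from compound 3 to compound 4 (within the scatter) is the first one shown that alters only the group on the amide-type nitrogen, and it lies within the scatter. Within this pair, then, propyl and cyclohexyl cannot be told apart at that nitrogen, even though cyclohexyl brings in a six-membered non-aromatic ring of carbon only and more heavy atoms than propyl. The compounds shown give no reason for this result.

As far as these compounds go, compound 2 still differs from each of the other compounds in more than one place, so it remains open whether its butyl group, its methoxy group or both go with the value of compound 2 at 43.7% in this read-out. From the compounds shown here alone, it is also open whether the same holds for other groups on this nitrogen, such as a phenyl ring, a hexyl chain or a chain ending in an amine or a carboxylic acid, and whether cyclohexyl would match propyl on the compound with hydrogen in place of methyl on the aromatic carbon.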